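This account rests on a few compounds, and the source may have more. Where it says the series, first, only, none or still open, it means among the compounds named here.

Notes on the series. Compound 2 `CCc1ccc(NC2=CC(=O)c3c(nc4n3[C@H]3OC[C@@H](O)[C@H]3OC4)C2=O)cc1` gives 6510 nM in a functional assay on HeLa cells (Homo sapiens) for inhibition, read by sulforhodamine B assay (a lower number here means a stronger inhibitor, a higher number a weaker inhibitor), the lower of the two numbers shown; compound 3 `CCOc1ccccc1NC1=CC(=O)c2c(nc3n2[C@H]2OC[C@@H](O)[C@H]2OC3)C1=O` gives 8300 nM, and the change a 1.3-fold higher number from compound 2 to compound 3 (0.11 log units; within the scatter) stays within the scatter. Compound 1 `O=C1C=C(NCc2ccccc2)C(=O)c2c1nc1n2[C@H]2OC[C@@H](O)[C@H]2OC1` gives > 8000 nM, which is the limit of > 8000 nM in this assay, at which 1 of the 3 values shown sits, a limit of the assay rather than a number.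

Compound 4 `CCCN(CCC)C1=CC(=O)c2c(nc3n2[C@H]2OC[C@@H](O)[C@H]2OC3)C1=O` is not yet measured. It differs from compound 2 by dipropylamino in place of (4-ethylphenyl)amino on a double-bonded ring carbon. Within the data shown here, the only measured step swaps one aryl amine for another and is within the scatter, so it says little about removing the ring altogether; compound 1, which lacks the aryl amine, sits at its limit. A weaker number is therefore expected for compound 4, with a 1.4-fold higher number from compound 2 to compound 4 (0.14 log units; within the scatter), giving an estimate of 9000 nM in this assay, between 3000 nM and 25000 nM, with a fair chance that only a limit is reported.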

Compound 4, half-maximal inhibitory concentration: > 16000 nM
Compound 4: no number, only a limit; the forecaster's own chance of this, stated with the estimate: 50%; middle value at least 1.7-fold (0.24 log units) from the limit.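

Dipropylamino in place of (4-ethylphenyl)amino, which removes the ring and the hydrogen-bond donor together, is the first change on this double-bonded ring carbon to read beyond the scatter in this assay, with an at least 2.4-fold higher number from compound 2 to compound 4 (0.39 log units; beyond the scatter). Compound 4 gives only a limit, not a number: the limit of > 16000 nM in this assay, at which 1 of the 4 values shown sits. As far as these compounds go, the full size of this step therefore stays unknown, and only its lower bound can be read.

The compounds shown leave open whether the loss of the ring or of the amine hydrogen accounts for the step. A propylamino group, which keeps the amine hydrogen without the ring, would bear on that.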